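Cytotoxicity notes: carbamate and amide analogues of one core

The source may hold more compounds than are shown below. What is called first, only, known or untested is meant among the compounds shown, and "the series" means these compounds.

Compound 1 `CCCCOC(=O)Nc1cc2nc(C3CCCCC3)[nH]c2cc1N(CC)CC` carries a carbamate on the shared core. In an ADME assay on Vero cells (Chlorocebus sabaeus) for cytotoxicity, read by resazurin assay, with a stated time of 3 days (on this read-out lower numbers stand for stronger inhibition and higher numbers for weaker inhibition), compound 1 gives only a limit, > 100 ug/mL. Compound 2 `CCCC(C)OC(=O)Nc1cc2nc(C3CCCCC3)[nH]c2cc1N(CC)CC` differs from it by methyl in place of hydrogen on a saturated chain carbon bound to an oxygen next to a carbonyl group and a saturated chain carbon. In this assay compound 2 likewise gives only a limit, > 100 ug/mL. The step that the two limits leave unreadable from compound 1 to compound 2 is therefore not readable in size. Compound 3 `CCN(CC)c1cc2[nH]c(C3CCCCC3)nc2cc1NC(=O)c1ccc(N(C)C)cc1` replaces the carbamate by an amide; in this assay compound 3 stands at "not determined" (no result reported), so no number places it, while the two remaining values sit at the limit of > 100 ug/mL in this assay, at which 2 of the 3 values shown sit. Compound 4 `C=Cc1cccc(C(=O)Nc2cc3nc(C4CCCCC4)[nH]c3cc2N(CC)CC)c1` differs from compound 3 by 3-vinylphenyl in place of 4-(dimethylamino)phenyl on a carbonyl carbon, on a carbonyl carbon whose other neighbours are an amide-type nitrogen. Going by the values given here, no measured step bears on this change, and the one step is unreadable, so no direction can be drawn from the data. Compound 4 is expected in this assay near 100 ug/mL, within 40 ug/mL to 250 ug/mL, most probably again as a limit.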

Compound 4, half-maximal inhibitory concentration: > 100 ug/mL
Compound 4: no number, only a limit; the forecaster's own chance of this, stated with the estimate: 70%; the middle value sits exactly at the limit.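

In this assay compound 4 gives only a limit, > 100 ug/mL. No new step can be read, as the steps from compound 1 and compound 2 to compound 4 stay unreadable. The compounds shown leave open whether any change on the carbonyl carbon shifts cytotoxicity at all: the limit of > 100 ug/mL in this assay, at which 3 of the 4 values shown sit.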